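The source may hold more compounds than are shown below. What is called first, only, known or untested is meant among the compounds shown, and "the series" means these compounds.

Measured so far:
- compound 1 `COc1ccc(CN(C(=O)CSc2nc3ccc(OC)cc3s2)c2cc(OC)c(OC)c(OC)c2)cc1`: > 80000 nM (a limit of the assay, not a number)
- compound 2 `COc1ccc(CN(C(=O)CCCSc2nc3ccccc3o2)c2cc(OC)c(OC)c(OC)c2)cc1`: 11000 nM

Within the data shown here, in a functional assay on ECa-109 cells for antiproliferative activity against ECa-109 cell line (Homo sapiens), read by MTT assay, with a stated time of 48 h (on this read-out higher numbers stand for weaker inhibition and lower numbers for stronger inhibition), compound 2 gives the only actual number, 11000 nM, so it cannot yet be ranked within a range of numbers. The other entry is a limit: the limit of > 80000 nM in this assay, at which 1 of the 2 values shown sits, which belongs to compound 1.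

The next compound is compound 3 `COc1ccc(CN(C(=O)CSc2nc3ccccc3o2)c2cc(OC)c(OC)c(OC)c2)cc1`, and its change from compound 2 is (1,3-benzoxazol-2-yl)sulfanyl in place of 2-((1,3-benzoxazol-2-yl)sulfanyl)ethyl on a saturated chain carbon bound to a carbonyl carbon. Among the measured compounds shown here, only one measured step bears on this place: an at least 7.2-fold lower number from compound 1 to compound 2 (0.86 log units; beyond the scatter). That step lies beyond the scatter, but it is an imperfect guide. Compound 1 shares the shorter chain with compound 3, while compound 2 has the longer one, and the group exchanged in that step also differs in other ways. Compound 3 keeps the (1,3-benzoxazol-2-yl)sulfanyl of compound 2, so only part of that step is expected to carry over, towards a higher number in this assay. The expected change is a 2.9-fold higher number from compound 2 to compound 3 (0.46 log units; beyond the scatter). For compound 3 the estimate is 32000 nM, with an expected range of 10000 nM to 100000 nM.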

Compound 3, half-maximal inhibitory concentration: 24800 nM
For compound 3 the middle estimate is 1.3-fold (0.11 log units) above the measured one; low and high end bracket the measured number.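

In this assay, (1,3-benzoxazol-2-yl)sulfanyl in place of 2-((1,3-benzoxazol-2-yl)sulfanyl)ethyl on a saturated chain carbon bound to a carbonyl carbon gives a 2.3-fold higher number from compound 2 to compound 3 (0.35 log units; beyond the scatter), so the chain change now has a reading of its own with the benzoxazole held constant, whereas the earlier step mixed it with a change of the ring group. With the shorter chain held constant, 1,3-benzoxazol-2-yl in place of 6-methoxy-1,3-benzothiazol-2-yl on a sulfur gives an at least 3.2-fold lower number from compound 1 to compound 3 (0.50 log units; beyond the scatter), so the ring group also counts separately from the chain. The value of compound 1 is a limit of the assay, not a number: the limit of > 80000 nM in this assay, at which 1 of the 3 values shown sits.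

The methoxy group and the benzothiazole ring change together in that second step, so their separate shares remain unresolved, and a plain 1,3-benzothiazol-2-yl on the sulfur would divide them. Also open, on these data alone, is whether the trend with chain length continues to a chain longer than that of compound 2, and how an amine in place of the sulfanyl link would read in this assay.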